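Extending the para substituent from methyl to a pyrrolidinylmethyl group

This account rests on a few compounds, and the source may have more. Where it says the series, first, only, none or still open, it means among the compounds named here.

Of the compounds shown here, three sharing one core have been measured in an assay on COS-7 cells for inhibition of patatin-like phospholipase domain-containing protein 2 (Mus musculus), tested at 200 uM; a lower number here means less inhibition, a higher number more inhibition at the concentration tested (going by the name of the read-out). Compound 1 `CCOC(=O)c1cccc(-c2ccc(OCC)cc2)c1` gives 87%. Compound 2 `CCOC(=O)c1cccc(-c2ccc([N+](=O)[O-])cc2)c1` gives 63%, and compound 3 `CCOC(=O)c1cccc(-c2ccc(C)cc2)c1` gives 63%. The change a number 24 percentage points lower from compound 1 to compound 2 (beyond the scatter) and the change a number 24 percentage points lower from compound 1 to compound 3 (beyond the scatter) both lowered the read-out beyond the scatter, while no change at the digits printed from compound 2 to compound 3 (within the scatter) lies within it. Compound 3 therefore stands level with compound 2, and the two together sit lowest of the three values, with compound 1 furthest away and higher.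

Compound 4 `CCOC(=O)c1cccc(-c2ccc(CN3CCCC3)cc2)c1` is not yet measured. It differs from compound 3 by pyrrolidin-1-yl in place of hydrogen on a saturated chain carbon bound to an aromatic carbon. Among the measured compounds shown here, none of the three measured steps concerns a saturated chain carbon bound to an aromatic carbon; all of them swap groups directly on the aromatic carbon, so no measured step bears on this change. With no guide, the expectation is a step from compound 3 to compound 4 of a number 3 percentage points lower from compound 3 to compound 4 (within the scatter), that is, none beyond the scatter in this assay. For compound 4 the estimated value is 60%, with a range from 35% to 85%.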

Compound 4, a percentage reported as inhibition, at one concentration (the size of the read-out at that concentration, not a potency): 33%
Compound 4: middle estimate off by 27 percentage points, on the high side; measured number below the stated range.
By their numbers in this assay, from the lowest: compound 4; then compounds 2 and 3 (each within the scatter of the next); then compound 1.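

In this assay the read-out moves with a change on the saturated chain carbon bound to an aromatic carbon, not only with swaps directly on the aromatic carbon: there is a number 30 percentage points lower from compound 3 to compound 4 (beyond the scatter) when methyl becomes (pyrrolidin-1-yl)methyl. The same group also compares poorly with the other two substituents, giving a number 30 percentage points lower from compound 2 to compound 4 (beyond the scatter) against nitro and a number 54 percentage points lower from compound 1 to compound 4 (beyond the scatter) against ethoxy, so compound 4 lies beyond the scatter under all three earlier compounds. Nothing measured here explains this fall.

The compounds shown leave open whether the fall follows the ring or the nitrogen, which a plain butyl chain or an open dimethylamino group on the same carbon could separate. Also open, as far as these compounds go, is how a morpholine ring in place of pyrrolidin-1-yl would read in this assay on this core.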